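The compounds below may be only part of what the source reports. "The series", "measured", "known", "first", "only" and "open" are said of these compounds alone.

In a physicochemical assay for lipophilicity, in phosphate buffer, measured as octanol-water partition, at pH 11.5 (on this read-out higher numbers stand for higher lipophilicity and lower numbers for lower lipophilicity), compound 1 `CCCCOC(=N)NC(=N)Nc1ccc(Cl)cc1` gives 3.32, while compound 2 `CC(C)OC(=N)NC(=N)Nc1ccc(Cl)cc1` gives 2.64, the lower of the two numbers. Within the data shown here, the one measured step, a number 0.68 log units lower from compound 1 to compound 2 (beyond the scatter), came with isopropyl in place of butyl on an oxygen on an unsaturated carbon.

The next compound, compound 3 `CCNC(=N)NC(=N)Nc1ccc(Cl)cc1`, has ethylamino in place of isopropoxy on a carbon with a double bond to nitrogen. Among the measured compounds shown here, no measured step shows an exchange of this kind, so the earlier step, a number 0.68 log units lower from compound 1 to compound 2 (beyond the scatter), is only a loose guide. For the measured compounds named here, it is still the sole measured change in this part of the structure, and it points downward. A drop of similar size is therefore expected, and the estimated step is a number 0.74 log units lower from compound 2 to compound 3 (beyond the scatter). For compound 3 the estimated value is 1.9, with an expected range from 1.3 to 2.5.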

Compound 3, partition coefficient: 2.14
Compound 3: middle estimate off by 0.24 log units, on the low side; the range from low to high includes it.
By their numbers in this assay, from the lowest: compound 3; then compound 2; then compound 1.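

Among these compounds, until now, the only measured change at this position kept an oxygen on the carbon with a double bond to nitrogen, whereas compound 3 shows that the number in this assay also moves when a nitrogen-linked group takes its place: ethylamino in place of isopropoxy gives a number 0.50 log units lower from compound 2 to compound 3 (beyond the scatter). Ethylamino in place of butoxy gives the largest step so far, a number 1.18 log units lower from compound 1 to compound 3 (beyond the scatter), and places the three compounds in the order butoxy, isopropoxy, ethylamino, from highest to lowest. No measurement here explains why the number falls with either exchange.

Ethylamino differs from both oxygen-linked groups in its linking atom and its carbon chain, so the share of each in these steps stays open. An ethoxy or butylamino group on the same carbon would separate the linking atom from the chain.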